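The compounds below may be only part of what the source reports. "The series", "measured", "known", "first", "only" and "open" are said of these compounds alone.

Measured so far in an ADME assay on PC-3 cells (Homo sapiens) for cytotoxicity, read by WST assay, tested at 100 uM; on this read-out lower numbers stand for less inhibition and higher numbers for more inhibition at the one concentration tested (going by the name of the read-out):
compound 1 `Cc1cccc(C(=O)N2CCCC(C(=O)Nc3ccc(Cl)cc3)C2)c1` — 0%
compound 2 `CCc1cccc(NC(=O)C2CCCN(C(=O)c3cc(C(F)(F)F)cc(C(F)(F)F)c3)C2)c1` — 0%
compound 3 `CC(=O)c1cccc(NC(=O)C2CCCN(C(=O)c3cc(C(F)(F)F)cc(C(F)(F)F)c3)C2)c1` — 0%

All three measured compounds sit at the same level in this assay, and compound 1 stands level with compounds 2 and 3. For the measured compounds named here, the single step between measured compounds, no change at the digits printed from compound 2 to compound 3 (within the scatter), left the read-out unchanged within the scatter.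

Compound 4 `CS(=O)(=O)c1cccc(C(=O)N2CCCC(C(=O)Nc3ccc(Cl)cc3)C2)c1` is not yet measured. Its difference from compound 1 is methylsulfonyl in place of methyl on an aromatic carbon. Going by the values given here, no measured step alters the same part of the core; the step from compound 2 to compound 3 bears only loosely on it, showing that one change on the aryl amide side of the shared core gave no shift. On that basis no step beyond the scatter is expected, a number 2 percentage points higher from compound 1 to compound 4 (within the scatter). Compound 4 is therefore expected to give about 2% in this assay, within -8% to 15%.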

Compound 4, a percentage reported as inhibition, at one concentration (the size of the read-out at that concentration, not a potency): 2%
The estimate for compound 4 equals the measured number at the digits printed; the measured number falls inside the stated range.
By their numbers in this assay, from the lowest: compounds 1, 2, 3 and 4 (each within the scatter of the next).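

In this assay, for the compounds shown here, methylsulfonyl in place of methyl on an aromatic carbon, meta to a large group, gives a number 2 percentage points higher from compound 1 to compound 4 (within the scatter) and is the first step read at this place on the shared core. A larger group bearing hydrogen-bond acceptors therefore leaves the read-out within the scatter here, which the earlier step, made elsewhere on the core, could not show. No supporting data bear on this result. As far as these compounds go, whether an amine or a carboxylic acid at this place would move the read-out beyond the scatter remains open.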